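This account rests on a few compounds, and the source may have more. Where it says the series, first, only, none or still open, it means among the compounds named here.

Measured so far in an ADME assay on TZM cells (Homo sapiens) for cytotoxicity, read by XTT assay, with a stated time of 4 days; a lower number here means that less compound is tolerated, a higher number that more compound is tolerated:
compound 1, `Cc1cc(N)cc(C)c1Oc1cc(Nc2ccc(C#N)cc2)c(N)cc1C(F)(F)F` — 15800 nM
compound 2, `CNC(=O)c1cc2ncn(-c3ccc(C#N)cc3)c2cc1Oc1c(C)cc(CCC#N)cc1C` — > 890000 nM, a limit of the assay
compound 3, `Cc1cc(/C=C/C#N)cc(C)c1Oc1cc(Nc2ccc(C#N)cc2)c(N)cc1S(N)(=O)=O` — > 21800 nM, a limit of the assay

Among the measured compounds shown here, compound 1 holds the only number among the three values. The other two are limits: the limit of > 890000 nM in this assay, at which 1 of the 3 values shown sits, for compound 2, and the limit of > 21800 nM in this assay, at which 1 of the 3 values shown sits, for compound 3. For the measured compounds named here, no pair of measured compounds differs in a single place, so no measured step is available.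

Compound 4, `Cc1cc(C#N)cc(C)c1Oc1cc(Nc2ccc(C#N)cc2)c(N)cc1C(F)(F)F`, is not yet measured. It differs from compound 1 by cyano in place of amino on an aromatic carbon. Going by the values given here, with no measured step to lean on, the expectation for the step from compound 1 to compound 4 is a 1.3-fold higher number from compound 1 to compound 4 (0.10 log units; within the scatter), within the usual scatter. Compound 4 is therefore expected to give 20000 nM, between 7000 nM and 60000 nM.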

Compound 4, half-maximal cytotoxic concentration: 13300 nM
Beside the measured number, compound 4's estimate is 1.5-fold (0.18 log units) above it; measured number inside the range.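

Cyano in place of amino on this aromatic carbon gives, in this assay, a 1.2-fold lower number from compound 1 to compound 4 (0.07 log units; within the scatter). Among the compounds shown here, this is the first single-place step, and it shows that, at this carbon, para to a large group, the two compounds cannot be told apart by this read-out, although amino carries a hydrogen-bond donor and cyano none. None of the measurements available speaks to why this is so.

As far as these compounds go, whether a carboxylic acid or a dimethylamino group on this carbon would give a step beyond the scatter remains open. From the compounds shown here alone, the contribution of the trifluoromethyl group also remains open, with no single-place comparison for it.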